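Turning one stereocentre in an aldosterone synthase inhibitor

The source may report more compounds than this note shows. Statements on the series, on what has been measured and on what is new or still open speak of the compounds shown alone.

Of the compounds shown here, two have been measured in an assay on cells for inhibition of cytochrome P450 11B2, mitochondrial (Homo sapiens), read by HTRF; a higher number here means a weaker inhibitor, a lower number a stronger inhibitor. Compound 1, with the structure `CC(=O)N[C@@H]1CCCc2c1cncc2N1C(=O)c2ccc(Cl)cc2[C@@H]1C1CC1`, gives 354 nM in this assay, the higher of the two numbers recorded. Compound 2, with the structure `CCC1c2cc(Cl)ccc2C(=O)N1c1cccnc1`, gives 121 nM in this assay, and the gap between these two values lies beyond the usual scatter. Compound 3, with the structure `CC(=O)N[C@@H]1CCCc2c1cncc2N1C(=O)c2ccc(Cl)cc2[C@H]1C1CC1`, has not yet been measured. Compound 3 differs from compound 1 only in configuration: the two compounds have the same atoms and bonds and differ only in configuration as drawn: 1 of 2 stereo elements differ; a stereocentre at a saturated ring carbon is drawn S in compound 1 and R in compound 3. Within the data shown here, no measured pair shows the effect of such an inversion here, so the size and direction of the step are open; such a change can leave the number nearly unchanged or shift it in either direction. On that basis the step from compound 1 to compound 3 is expected to be a 1.3-fold higher number from compound 1 to compound 3 (0.10 log units; within the scatter), with a wide range. In this assay compound 3 is therefore estimated at 450 nM, between 110 nM and 2000 nM.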

Compound 3, half-maximal inhibitory concentration: 100 nM
Estimate against measurement, compound 3: 4.5-fold (0.65 log units) above, and the stated range ends above it.
By their numbers in this assay, from the lowest: compounds 3 and 2 (each within the scatter of the next); then compound 1.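

In this assay, inverting this saturated ring carbon from S to R gives a 3.5-fold lower number from compound 1 to compound 3 (0.55 log units; beyond the scatter), so the drawn configuration at this position matters for inhibition, and of this pair the R form is the stronger inhibitor. The shift can be assigned to this one stereocentre alone because no atom or bond is gained or lost: the fact that compounds 1 and 3 differ only in the configuration as drawn. The earlier compounds shown here offered no such matched pair, so they could not separate the effect of configuration from the effect of other structural differences.

From the compounds shown here alone, only one of the two stereo elements has been turned here, so the effect of inverting the other one remains open. It is also unknown whether R would still be preferred if a longer chain, such as a butyl group, stood on this ring carbon.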